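Halo-substituted ketones in an adenosine receptor A3 binding series

This account rests on a few compounds, and the source may have more. Where it says the series, first, only, none or still open, it means among the compounds named here.

Measured so far:
compound 1 `Nc1sc2c(c1C(=O)c1ccc(I)c3ccccc13)CCC2`: 0%
compound 2 `Nc1sc2c(c1C(=O)c1cccc3ccccc13)CCCC2`: 34.5%

In an assay on isolated protein with adenosine receptor A3 (Homo sapiens) as the target, tested at 10 uM (a higher number here means more inhibition at the concentration tested (going by the name of the read-out), a lower number less inhibition), compound 2 gives 34.5% and stands highest of the two numbers; compound 1, in the same assay, gives 0%, a gap beyond the scatter. The two differ in more than one place, so no single step can be read from them.

Compound 3 `Nc1sc2c(c1C(=O)c1ccc(Cl)c3ccccc13)CCCC2` is still to be measured. It differs from compound 2 by chloro in place of hydrogen on an aromatic carbon.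

A small downward step or none beyond the scatter is expected from compound 2 to compound 3, a number 9.5 percentage points lower from compound 2 to compound 3 (within the scatter). For compound 3 the expected value is 25%, within 5% to 45%.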

Compound 3, a percentage reported as inhibition, at one concentration (the size of the read-out at that concentration, not a potency): 30.5%
Compound 3: the middle estimate sits 5.5 percentage points below what was measured, and the stated range covers the measured number.
By their numbers in this assay, from the lowest: compound 1; then compounds 3 and 2 (each within the scatter of the next).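

In this assay, among the compounds shown here, chloro in place of hydrogen on an aromatic carbon, para to a large group, amounts to a number 4 percentage points lower from compound 2 to compound 3 (within the scatter) and is the only single-place step available in this set. This position therefore accepts chloro with no change beyond the scatter, which the pair of compound 1 and compound 2 could not show. Nothing measured here bears on the reason for this result.

Going by these compounds, whether bromo, an amine or a carboxylic acid at this position would give a similar number remains open. Also open, on these data alone, is whether chloro would behave alike on the core of compound 1.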